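This account rests on a few compounds, and the source may have more. Where it says the series, first, only, none or still open, it means among the compounds named here.

In an assay on membranes from HeLa cells for displacement of a labelled ligand from adenosine receptor A3 (Homo sapiens), read by scintillation counting, with a stated time of 180 min, tested at 1 uM (a higher number here means more inhibition at the concentration tested (going by the name of the read-out), a lower number less inhibition), compound 3 `CCN(CC)C(=O)C1=C(C)NC(=O)NC1c1cccs1` gives 31%, the highest of the three numbers recorded. Compound 2 `CCN(CC)C(=O)C1=C(C)NC(=O)NC1c1ccco1` gives 19%, and compound 1 `CC1=C(C(=O)CC(C)C)C(c2ccsc2)NC(=O)N1`, which carries a different side chain on the shared core, gives 14%. Going by the values given here, the only single-point step, a number 12 percentage points higher from compound 2 to compound 3 (beyond the scatter), concerns the aromatic group on the saturated ring carbon. Compound 4 `CCN(CC)C(=O)C1=C(C)NC(=O)NC1c1ccsc1` carries the change (thiophen-3-yl in place of thiophen-2-yl on a saturated ring carbon). Among the compounds with values here, no measured step bears directly on moving the attachment point within the thiophene; the nearest comparison exchanges one five-membered aromatic ring for another and is modest. A step of at most that size in this assay, in either direction, is therefore expected. Compound 4 is estimated at 25%, in a range from 10% to 40%. The expected step of a number 6 percentage points lower from compound 3 to compound 4 (within the scatter) stays within the scatter.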

Compound 4, a percentage reported as inhibition, at one concentration (the size of the read-out at that concentration, not a potency): 35%
Compound 4: middle estimate off by 10 percentage points, on the low side; measured number inside the range.
By their numbers in this assay, from the lowest: compounds 1 and 2 (each within the scatter of the next); then compounds 3 and 4 (each within the scatter of the next).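

In this assay, moving the attachment point within the thiophene gives a number 4 percentage points higher from compound 3 to compound 4 (within the scatter) and so separates the two thiophene isomers by no readable margin, while thiophen-3-yl, like thiophen-2-yl, stands clear of the furan, with a number 16 percentage points higher from compound 2 to compound 4 (beyond the scatter) as the step. The side chain on the carbonyl carbon now has its first comparison in one place, diethylamino in place of isobutyl giving a number 21 percentage points higher from compound 1 to compound 4 (beyond the scatter) on the thiophen-3-yl compounds. No evidence is at hand to explain these steps. Open, going by these compounds, is whether phenyl or pyridyl on the saturated ring carbon would hold this level. Also open, on these data alone, is how a piperidine amide or a longer chain on the carbonyl carbon would compare with diethylamino.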